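The compounds below may be only part of what the source reports. "The series", "measured", "known", "first", "only" and "open" are said of these compounds alone.

Measured compounds and values in an ADME assay on KB cells (Homo sapiens) for cytotoxicity, read by MTT assay, with a stated time of 44 h; a lower number here means a stronger inhibitor, a higher number a weaker inhibitor:

Compound 1, `CCCCNC(=S)N1CC(C)C(c2ccccc2)=N1`, gives > 100000 nM, which is a limit of this assay and not a number.
Compound 2, `CC(C)CNC(=S)N1CC(C)C(c2ccccc2)=N1`, gives > 100000 nM, likewise a limit.
Compound 3, `CC1CN(C(=S)N2CCN(c3ccccc3)CC2)N=C1c1ccccc1`, gives > 100000 nM, again a limit.

Compound 2 therefore stands at the limit, and nothing places it above or below compound 1 or compound 3: all three values sit on the same line, as shown by the limit of > 100000 nM in this assay, at which 3 of the 3 values shown sit. For the measured compounds named here, the one step among measured compounds that differ in a single place is a step that the two limits leave unreadable from compound 1 to compound 2; its two limits leave it without a readable size, so it gives no lead on how changes on the thiourea nitrogen move the numbers.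

Compound 4, `Cc1ccccc1NC(=S)N1CC(C)C(c2ccccc2)=N1`, carries the change (2-methylphenyl in place of isobutyl on an amide-type nitrogen). Going by the values given here, no measured step bears on an aromatic group in this place, and the only comparable step is unreadable. The account expects for compound 4 a step that the limit leaves unreadable from compound 2 to compound 4 that cannot be read as beyond the scatter. Compound 4 is estimated at 150000 nM, within 40000 nM to 600000 nM, most likely again a limit.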

Compound 4, half-maximal inhibitory concentration: > 100000 nM
Compound 4 was reported as a limit (the forecaster's own chance of this, stated with the estimate: 70%); the middle value does not contradict the limit.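

Compound 4 adds no readable step, and its steps from compound 1 and from compound 2 cannot be read, as all these compounds stand at the same limit: the limit of > 100000 nM in this assay, at which 4 of the 4 values shown sit. The compounds shown leave open whether any group on the amide-type nitrogen moves the value at all.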